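The source may report more compounds than this note shows. Statements on the series, on what has been measured and on what is new or still open speak of the compounds shown alone.

Compound 1, `CCCCCCCC(=O)OCC1CN(C(=O)c2cc(OC)c(OC)c(OC)c2)CCN1C(=O)c1cc(OC)c(OC)c(OC)c1`: 310 nM
Compound 2, `CCCCCCCCCCCCCCCCCC(=O)OCC1CN(C(=O)c2cc(OC)c(OC)c(OC)c2)CCN1C(=O)c1cc(OC)c(OC)c(OC)c1`: 45000 nM
Compound 3, `COc1cc(C(=O)N2CCN(C(=O)c3cc(OC)c(OC)c(OC)c3)C(COC(=O)C(C)(C)C)C2)cc(OC)c1OC`: 100 nM; 100 nM; 120 nM (3 entries)

All three were tested in a functional assay (Oryctolagus cuniculus) for inhibition of platelet-activating factor receptor (Cavia porcellus); on this read-out higher numbers stand for weaker inhibition and lower numbers for stronger inhibition. Among the two single numbers, compound 1 gives the lower one; its nearest neighbour, compound 2, lies a 150-fold higher number from compound 1 to compound 2 (2.16 log units; beyond the scatter), the only measured step in this set, made by putting decyl in place of hydrogen far along the ester chain. Compound 3 was measured repeatedly, (the several entries of compound 3 in this assay, 100 nM; 100 nM; 120 nM (3 entries)), and so has no single number of its own.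

Compound 4, `COc1cc(C(=O)N2CCN(C(=O)c3cc(OC)c(OC)c(OC)c3)C(COC(=O)CC(C)(C)C)C2)cc(OC)c1OC`, is made from compound 1 by tert-butyl in place of hexyl on a saturated chain carbon bound to a carbonyl carbon; cut one bond further out, the change reads heptyl to neopentyl. The ester chain of compound 4 is thus shorter than that of compound 1, and tert-butyl, as in compound 3, is only one bond further from the carbonyl. The measured step from compound 1 to compound 2 shows that a much longer chain goes with a far higher number, while compound 3, carrying the shortest ester group, gives the lowest values seen. A small step, toward a somewhat lower number at most, is expected here, a 2.1-fold lower number from compound 1 to compound 4 (0.32 log units; beyond the scatter). Compound 4 is estimated at 150 nM, within a range from 60 nM to 400 nM.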

Compound 4, half-maximal inhibitory concentration: 120 nM
For compound 4 the middle estimate is 1.3-fold (0.10 log units) above the measured one, within the range that was stated.
By their numbers in this assay, from the lowest: compound 4; then compound 1; then compound 2.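

In this assay, putting tert-butyl in place of hexyl on a saturated chain carbon bound to a carbonyl carbon gives a 2.6-fold lower number from compound 1 to compound 4 (0.41 log units; beyond the scatter), a modest step. It is small beside a 150-fold higher number from compound 1 to compound 2 (2.16 log units; beyond the scatter), and it runs the other way, so this position now has a measured step toward stronger inhibition as well as one toward weaker inhibition. Across compound 2, compound 1 and compound 4, the number falls as the group at this place gets smaller, with no compound among these three going against that order, and compound 4, at 120 nM, shows a value that also stands among the entries of compound 3: the several entries of compound 3 in this assay, 100 nM; 100 nM; 120 nM (3 entries)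

The compounds shown leave open whether the lower number follows the smaller size of tert-butyl or its branched shape, a question that a straight butyl chain would help to settle. They also leave open how an amine or a carboxylic acid at this place, or an amide in place of the ester, would read in this assay.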